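Phenyl for methyl on the core of compound 3

The compounds below may be only part of what the source reports. "The series", "measured", "known", "first", "only" and "open" are said of these compounds alone.

For the measured compounds named here, compound 3 `CCCCN(CC)c1nc(C)nc2c1nc(C)n2-c1c(Cl)cc(OC)cc1OC` gives 3.5 nM in an in vitro assay on 293-EBNA cells for binding affinity to corticotropin-releasing factor receptor 1 (Homo sapiens) (a lower number here means a stronger inhibitor, a higher number a weaker inhibitor), the lowest of the three numbers measured so far. Compound 2 `CCCC(CCC)Nc1nc(C)nc2c1nnn2-c1c(C)cc(C)cc1C` gives 4 nM, a value within the scatter of compound 3, while compound 1 `COCCNc1nc(C)nc2c1nnn2-c1c(C)cc(C)cc1C` gives 1200 nM, far higher than either. Going by the values given here, the only measured step, a 300-fold lower number from compound 1 to compound 2 (2.48 log units; beyond the scatter), concerns the group on the amine nitrogen, not the position altered here. Compound 4 `CCCCN(CC)c1nc(C)nc2c1nc(-c1ccccc1)n2-c1c(Cl)cc(OC)cc1OC` differs from compound 3 by phenyl in place of methyl on an aromatic carbon. Among the compounds with values here, no measured step speaks to this position, so no shift beyond the scatter is expected. Compound 4 is therefore estimated to give about 5 nM, with a likely range from 1.5 nM to 20 nM. This amounts to an expected step of a 1.4-fold higher number from compound 3 to compound 4 (0.15 log units; within the scatter), within the scatter.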

Compound 4, inhibition constant: 133 nM
Compound 4: middle estimate off by 27-fold (1.42 log units), on the low side; the whole stated range lies below it.
By their numbers in this assay, from the lowest: compounds 3 and 2 (each within the scatter of the next); then compound 4; then compound 1.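

Methyl and phenyl are not interchangeable at this position, on an aromatic carbon between two ring nitrogen atoms. In this assay phenyl in place of methyl gives a 38-fold higher number from compound 3 to compound 4 (1.58 log units; beyond the scatter) and so marks a large move towards a weaker inhibitor. This shows that a change on the core, and not only on the amine nitrogen, can shift the number by a large step, though no evidence here explains the loss. On these data alone, whether ethyl, a longer chain or a pyridine ring here would stay close to compound 3 remains open. So does whether phenyl carrying a methoxy group would fare any differently from plain phenyl.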